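Trading two fluorines for one chlorine

This account rests on a few compounds, and the source may have more. Where it says the series, first, only, none or still open, it means among the compounds named here.

Compound 2 `O=C(NC(c1ccc(F)c(F)c1)C1CCNCC1)c1ccc2cnccc2c1` gives 2680 nM in an assay on isolated protein for inhibition of RAC-alpha serine/threonine-protein kinase (Homo sapiens) (a higher number here means a weaker inhibitor, a lower number a stronger inhibitor), the highest of the three numbers measured, though its gap to compound 1 is within the scatter. Compound 1 `O=C(NC(c1nccs1)C1CCNCC1)c1ccc2cnccc2c1` gives 1570 nM, and compound 3 `O=C(NC(c1cccc(Cl)c1)C1CCNCC1)c1ccc2cnccc2c1` gives 70 nM. The measured steps run a 38-fold lower number from compound 2 to compound 3 (1.58 log units; beyond the scatter), a 22-fold lower number from compound 1 to compound 3 (1.35 log units; beyond the scatter) and a 1.7-fold higher number from compound 1 to compound 2 (0.23 log units; within the scatter). Compound 4 `O=C(NC(c1ccc(Cl)cc1)C1CCNCC1)c1ccc2cnccc2c1` carries a related change: 4-chlorophenyl in place of 3,4-difluorophenyl on a saturated chain carbon bound to an amide-type nitrogen and a saturated ring carbon. Both large measured steps concern 3-chlorophenyl, not 4-chlorophenyl, so a lower number than that of compound 2 is expected for a chlorophenyl in this place, but its size is uncertain because a 38-fold lower number from compound 2 to compound 3 (1.58 log units; beyond the scatter) rests on a different chlorophenyl. Compound 4 is expected to give 300 nM, between 60 nM and 1500 nM, an expected step of an 8.9-fold lower number from compound 2 to compound 4 (0.95 log units; beyond the scatter).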

Compound 4, half-maximal inhibitory concentration: 190 nM
Beside the measured number, compound 4's estimate is 1.6-fold (0.20 log units) above it; the measured number falls inside the stated range.
By their numbers in this assay, from the lowest: compound 3; then compound 4; then compounds 1 and 2 (each within the scatter of the next).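

The large gain is not limited to 3-chlorophenyl: 4-chlorophenyl also beats 3,4-difluorophenyl (a 14-fold lower number from compound 2 to compound 4 (1.15 log units; beyond the scatter)) and 1,3-thiazol-2-yl (an 8.3-fold lower number from compound 1 to compound 4 (0.92 log units; beyond the scatter)). Where the chlorine sits on the ring still matters, but more modestly (a 2.7-fold higher number from compound 3 to compound 4 (0.43 log units; beyond the scatter)). No supporting data here explain these differences.

The compounds shown leave open how a plain phenyl would compare, and so whether the chlorine itself brings the gain. A phenyl carrying a methoxy group or an amine at this place also remains to be compared.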